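The compounds below may be only part of what the source reports. "The series", "measured", "known", "first", "only" and "open" are said of these compounds alone.

Compound 2, with the structure `C=CC(=O)Nc1cccc(NC(=O)CSc2nc(Nc3ccccc3)c3ccccc3n2)c1`, gives 10200 nM in a functional assay on MDA-MB-231 cells (Homo sapiens) for inhibition, read by MTT assay, with a stated time of 72 h (a lower number here means a stronger inhibitor, a higher number a weaker inhibitor), the lowest of the three numbers shown. Compound 1, `COc1cccc(NC(=O)CSc2nc(Nc3ccccc3)c3ccccc3n2)c1`, gives 21700 nM, and compound 3, `O=C(CSc1nc(Nc2ccccc2)c2ccccc2n1)Nc1ccc([N+](=O)[O-])cc1`, gives 16800 nM. The step of a 2.1-fold lower number from compound 1 to compound 2 (0.33 log units; beyond the scatter) is the only one beyond the scatter; the steps of a 1.3-fold lower number from compound 1 to compound 3 (0.11 log units; within the scatter) and a 1.6-fold higher number from compound 2 to compound 3 (0.22 log units; within the scatter) stay within it.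

The unmeasured compound 4, `C=CC(=O)Nc1cccc(NC(=O)CSc2nc(Nc3ccc(Cl)cc3)c3ccccc3n2)c1`, differs from compound 2 by chloro in place of hydrogen on an aromatic carbon. Going by the values given here, all three measured steps concern the aryl group on the amide-type nitrogen, and none touches the anilino ring, so no measured step bears directly on this change. With no evidence either way, compound 4 is expected to behave much like compound 2, the step of a 1.0-fold lower number from compound 2 to compound 4 (0.01 log units; within the scatter) being expected to fall within the scatter. Compound 4 is therefore estimated at 10000 nM in this assay, with a range from 4000 nM to 25000 nM.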

Compound 4, half-maximal inhibitory concentration: 10300 nM
Compound 4: middle estimate off by 1.0-fold (0.01 log units), on the low side; the range from low to high includes it.
By their numbers in this assay, from the lowest: compounds 2, 4, 3 and 1 (each within the scatter of the next, the first and the last beyond it).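

Going by these compounds alone, replacing anilino with (4-chlorophenyl)amino gives the first reading on this part of the molecule, as the earlier steps all concerned the aryl group on the amide-type nitrogen. In this assay, the result is a 1.0-fold higher number from compound 2 to compound 4 (0.00 log units; within the scatter), so chloro in this place, para to a large group, leaves the number where compound 2 had it. No evidence is available that would account for this result.

It remains open whether a carboxylic acid or an amine in the same place would also leave the number unmoved, since chloro is the only group shown there. As far as these compounds go, it is equally open whether chloro would give the same outcome with 3-methoxyphenyl or 4-nitrophenyl on the amide-type nitrogen in place of the 3-((vinylcarbonyl)amino)phenyl group.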